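Shifting methyl groups on the amide ring

A few compounds are considered here, and "the series" means these few. Any claim that something is new, unique, unknown or untested is made for them only; others in the source may bear on it.

Compound 1 `O=C(/C=C/c1cccc(NC(=O)c2ccccc2Cl)c1)c1nc2ccccc2[nH]1` and compound 2 `Cc1ccccc1C(=O)Nc1cccc(/C=C/C(=O)c2nc3ccccc3[nH]2)c1` share one core and differ only at the aryl amide. In a functional assay on HCT-116 cells (Homo sapiens) for antiproliferative activity, read by MTT assay, with a stated time of 48 h (a higher number here means a weaker inhibitor, a lower number a stronger inhibitor), compound 1 gives 1280 nM, and compound 2 gives 1870 nM; the step of a 1.5-fold higher number from compound 1 to compound 2 (0.16 log units; within the scatter) is within the scatter, so compound 2 stands level with compound 1. Compound 3 `Cc1cc(C)cc(C(=O)Nc2cccc(/C=C/C(=O)c3nc4ccccc4[nH]3)c2)c1` carries 3,5-dimethylphenyl in place of 2-methylphenyl on a carbonyl carbon. For the measured compounds named here, the one measured step changed that same ring only modestly, so no step beyond the scatter is expected for compound 3, estimated as a 1.1-fold higher number from compound 2 to compound 3 (0.03 log units; within the scatter). Compound 3 is expected to give about 2000 nM, between 900 nM and 4500 nM.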

Compound 3, half-maximal inhibitory concentration: 1550 nM
Compound 3: middle estimate off by 1.3-fold (0.11 log units), on the high side; low and high end bracket the measured number.
By their numbers in this assay, from the lowest: compounds 1, 3 and 2 (each within the scatter of the next).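

In this assay, 3,5-dimethylphenyl in place of 2-methylphenyl gives a 1.2-fold lower number from compound 2 to compound 3 (0.08 log units; within the scatter) and, in place of 2-chlorophenyl, gives a 1.2-fold higher number from compound 1 to compound 3 (0.08 log units; within the scatter) as its two steps. This position on the carbonyl carbon therefore accepts a phenyl ring carrying two methyl groups, and all three aryl groups stand level. Nothing measured here says why these compounds stand level. The compounds shown leave open whether an amine or a carboxylic acid on this ring would move the number beyond the scatter. The same question holds for a longer chain in place of methyl.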